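Adding a triazolyl group to compound 1

The source may report more compounds than this note shows. Statements on the series, on what has been measured and on what is new or still open speak of the compounds shown alone.

In a functional assay on A549 cells (Homo sapiens) for antiproliferative activity, read by sulforhodamine B assay, with a stated time of 72 h (on this read-out lower numbers stand for stronger inhibition and higher numbers for weaker inhibition), compound 1 (`COc1c(OC(C)C)cc2occ(-c3csc4ccccc34)c(=O)c2c1OC(C)C`) gives 8900 nM, within the scatter of compound 2 (`COc1c(OC(C)C)cc2occ(-c3csc4ccccc34)c(=O)c2c1O`) at 7200 nM. Compound 3 (`COc1c(OC(C)C)cc2occ(-c3ccccc3)c(=O)c2c1OC(C)C`) reaches only a limit, > 10000 nM. Compound 4 (`COc1c(OC(C)C)cc2oc(-n3cncn3)c(-c3csc4ccccc34)c(=O)c2c1OC(C)C`) differs from compound 1 in one place: 1H-1,2,4-triazol-1-yl in place of hydrogen on an aromatic carbon. The new 1H-1,2,4-triazol-1-yl sits on an aromatic carbon, ortho to the 1-benzothiophen-3-yl group. The two measured steps, a 1.2-fold lower number from compound 1 to compound 2 (0.09 log units; within the scatter) and an at least 1.1-fold higher number from compound 1 to compound 3 (0.05 log units; that floor lies within the scatter), change other places and stay within the scatter, so they suggest no direction here. The expected change, no larger than the scatter, is a 1.1-fold lower number from compound 1 to compound 4 (0.05 log units; within the scatter). For compound 4 the estimated value is 8000 nM, with an expected range from 2500 nM to 25000 nM.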

Compound 4, half-maximal inhibitory concentration: > 10000 nM
Compound 4: no number, only a limit; the forecaster's own chance of this, stated with the estimate: 40%; middle value at least 1.2-fold (0.09 log units) away from the limit.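

Compound 4 gives no number in this assay, only a limit of > 10000 nM. The step, an at least 1.1-fold higher number from compound 1 to compound 4 (0.05 log units; that floor lies within the scatter), has a floor within the scatter, so 1H-1,2,4-triazol-1-yl on this aromatic carbon next to the ring oxygen shows no gain over hydrogen, and the size of any loss cannot be read: the limit of > 10000 nM in this assay, at which 2 of the 4 values shown sit.

On these data alone, whether an amine or a methyl group on this carbon would give a measurable number remains open. So does whether a carboxylic acid there would differ from 1H-1,2,4-triazol-1-yl.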